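The source may report more compounds than this note shows. Statements on the series, on what has been measured and on what is new or still open speak of the compounds shown alone.

Compound 1 `O=c1c(CSC(=S)N2CCCC2)coc2ccccc12` and compound 2 `O=c1c(CSC(=S)N2CCCC2)coc2cc(Cl)ccc12` share one core and differ only by chloro in place of hydrogen on an aromatic carbon. In a functional assay on HEp-2 cells (Homo sapiens) for antiproliferative activity, read by MTT assay, with a stated time of 72 h (on this read-out higher numbers stand for weaker inhibition and lower numbers for stronger inhibition), compound 1 gives 3600 nM and compound 2 gives 2100 nM. Compound 1 holds the higher of the two numbers, yet the step of a 1.7-fold lower number from compound 1 to compound 2 (0.23 log units; within the scatter) is within the scatter, so the two cannot be told apart. Compound 3 `O=c1c(CSC(=S)N2CCCCC2)coc2ccccc12` differs from compound 1 by piperidin-1-yl in place of pyrrolidin-1-yl on a thiocarbonyl carbon. Among the measured compounds shown here, no measured step touches this ring change, so no shift beyond the scatter is expected in this assay. For compound 3 the estimate is 3600 nM, with a range from 1500 nM to 8500 nM. This amounts to an expected step of no change at the digits printed from compound 1 to compound 3 (within the scatter).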

Compound 3, half-maximal inhibitory concentration: 390 nM
Beside the measured number, compound 3's estimate is 9.2-fold (0.97 log units) above it; the measured number lies below the stated range.
By their numbers in this assay, from the lowest: compound 3; then compounds 2 and 1 (each within the scatter of the next).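

At the thiocarbonyl carbon, the amine ring matters: piperidin-1-yl in place of pyrrolidin-1-yl gives a 9.2-fold lower number from compound 1 to compound 3 (0.97 log units; beyond the scatter) in this assay and so lies beyond the scatter, unlike the chloro change on the aromatic carbon. A small change in ring size at this place can therefore shift the number clearly, at least in this single pair. Nothing available explains this shift. Open, going by these compounds, is how azepan-1-yl or morpholin-4-yl would behave at this place. Also open, on these data alone, is whether the piperidin-1-yl step would hold with chloro on the shared core.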